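Acetamide to pivalamide swap carried across two cores

The source may hold more compounds than are shown below. What is called first, only, known or untested is meant among the compounds shown, and "the series" means these compounds.

Measured in a functional assay on K562 cells (Homo sapiens) for inhibition, read by MTT assay, with a stated time of 48 h; on this read-out higher numbers stand for weaker inhibition and lower numbers for stronger inhibition:
compound 1 `CC(C)(C)C(=O)Nc1ccc(-c2ccc(C(=O)N[C@H]3CN[C@@H](C(=O)Nc4ccc(Cl)c(C(F)(F)F)c4)C3)cc2)cn1`: 11600 nM
compound 2 `CC(=O)Nc1ccc(-c2ccc(C(=O)N[C@H]3CN[C@@H](C(=O)Nc4ccc(Cl)c(C(F)(F)F)c4)C3)cc2)cn1`: 22800 nM
compound 3 `CC(=O)Nc1ccc(-c2ccc(C(=O)N[C@@H](C)C(=O)Nc3ccc(Cl)c(C(F)(F)F)c3)cc2)cn1`: 107000 nM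

Compound 1 and compound 2 share one core; compound 3 has another, and the difference between the two cores is not broken down here. In this assay compound 3 stands highest of the three numbers, beyond the scatter from both others. From compound 2 to compound 1 the change is tert-butyl in place of methyl on a carbonyl carbon, and the step is a 2.0-fold lower number from compound 2 to compound 1 (0.29 log units; within the scatter).

Compound 4 `C[C@H](NC(=O)c1ccc(-c2ccc(NC(=O)C(C)(C)C)nc2)cc1)C(=O)Nc1ccc(Cl)c(C(F)(F)F)c1` is not yet measured in this assay. From compound 3 to compound 4 the change is tert-butyl in place of methyl on a carbonyl carbon, the same change at the same place as before. The expectation for compound 4 rests on that single earlier step, a 2.0-fold lower number from compound 2 to compound 1 (0.29 log units; within the scatter), so the estimated step is a 1.9-fold lower number from compound 3 to compound 4 (0.29 log units; within the scatter). Compound 4 is therefore expected to give 55000 nM, with an estimated range from 25000 nM to 130000 nM.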

Compound 4, half-maximal inhibitory concentration: 7450 nM
Estimate against measurement, compound 4: 7.4-fold (0.87 log units) above, outside the stated range (below it).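

In this assay, tert-butyl in place of methyl on the carbonyl carbon gives a 14-fold lower number from compound 3 to compound 4 (1.16 log units; beyond the scatter), and the size of this step does not carry over from one core to the other: the same change on two cores in this assay, a 2.0-fold lower number (0.29 log units; within the scatter) from compound 2 to compound 1 and a 14-fold lower number (1.16 log units; beyond the scatter) from compound 3 to compound 4, 7.3-fold (0.86 log units) apart, beyond the scatter of two such steps. Among the compounds shown here, only the step on the core of compound 3 lies beyond the scatter, while the step on the core of compound 1 cannot be told apart from no change. With one pair on each core, these data do not show why the step differs, nor what it would be on a third core.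

The compounds shown leave open what an isopropyl or a cyclopropyl group would give in the same place on either core. They also leave open which part of the difference between the two cores goes with the larger step.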